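A Substituent Swap on the Shared Core

The source may hold more compounds than are shown below. What is called first, only, known or untested is meant among the compounds shown, and "the series" means these compounds.

Compound 1 `CC1CCCN1c1ccc2cc(NC(=O)CCc3ccc(C(F)(F)F)cc3)ccc2n1` is measured in an assay on isolated protein for displacement of a labelled ligand from melanin-concentrating hormone receptor 1 (Homo sapiens) (on this read-out lower numbers stand for stronger inhibition and higher numbers for weaker inhibition), where compound 1 gives 5 nM. Compound 2 `O=C(CCCCCCCCCCCCc1ccc(C(F)(F)F)cc1)Nc1ccc2nc([N+]34CCC(CC3)CC4)ccc2c1` is built on the same core but differs from compound 1 in several places; in this assay compound 2 gives 5 nM. Compound 1 thus stands level with compound 2 at the digits shown, the two values lying within the scatter of each other, so no order between them can be claimed. Compound 3 `CC(=O)NC1CCN(c2ccc3cc(NC(=O)CCc4ccc(C(F)(F)F)cc4)ccc3n2)C1` has not yet been measured. It differs from compound 1 in a single place: 3-acetamidopyrrolidin-1-yl in place of 2-methylpyrrolidin-1-yl on an aromatic carbon. Among the compounds with values here, no measured pair tracks this particular change, so the size of the step in this assay rests on expectation alone. The author expects a small step downward in potency from compound 1 to compound 3, a 2.0-fold higher number from compound 1 to compound 3 (0.30 log units; within the scatter), not clearly beyond the scatter. Compound 3 is accordingly expected to give 10 nM in this assay, within a range from 3 nM to 40 nM.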

Compound 3, half-maximal inhibitory concentration: 5 nM
Estimate against measurement, compound 3: 2.0-fold (0.30 log units) above, and the stated range covers the measured number.
By their numbers in this assay, from the lowest: compounds 1, 2 and 3 (each within the scatter of the next).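

In this assay, 3-acetamidopyrrolidin-1-yl in place of 2-methylpyrrolidin-1-yl on the aromatic carbon next to the ring nitrogen gives no change at the digits printed from compound 1 to compound 3 (within the scatter). Within the data shown here, this is the first step that changes this position alone, since compound 2 differs from compound 1 in several places. It shows that the position can carry the larger group, with its added hydrogen-bond donor and acceptor, while the value stays within the scatter, and no measurement on hand accounts for this result.

The compounds shown leave open whether a free amine, a carboxylic acid or a longer chain in place of the acetamido part of 3-acetamidopyrrolidin-1-yl would also stay within the scatter of compound 3. They also leave open whether this step would hold if the amide chain of compound 1 were changed as well.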